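A Single Change from Compound 1 to Compound 3

The compounds below may be only part of what the source reports. "The series", "measured", "known", "first", "only" and "open" are said of these compounds alone.

Compound 1 `Cc1ccc(-c2ccsc2S(=O)(=O)NCCNC(=O)Nc2cccc([N+](=O)[O-])c2)c(Oc2ccc(O)c(O)c2)c1` and compound 2 `O=C(NCCNS(=O)(=O)c1ccc(-c2ccccc2O[C@H]2CC[C@@H](O)CC2)s1)Nc1cc(C(F)(F)F)cc(C(F)(F)F)c1` were both tested in a functional assay on HL-60 cells (Homo sapiens) for inhibition, read by CCK-8 assay, with a stated time of 48 h; on this read-out higher numbers stand for weaker inhibition and lower numbers for stronger inhibition. In this assay compound 1 gives 6000 nM, and compound 2 gives 3100 nM. Compound 1 carries the larger of these two numbers, yet the gap to compound 2 stays within the usual scatter. Compound 3 `Cc1ccc(-c2ccsc2S(=O)(=O)NCCNC(=S)Nc2cccc([N+](=O)[O-])c2)c(Oc2ccc(O)c(O)c2)c1` differs from compound 1 in one place: a group of 12 heavy atoms (7 carbon, 2 nitrogen, 2 oxygen, 1 sulfur; one six-membered aromatic ring of carbon only) in place of a group of 12 heavy atoms (7 carbon, 2 nitrogen, 3 oxygen; one six-membered aromatic ring of carbon only), on an amine nitrogen. For the measured compounds named here, no measured pair shows this change, so the step is expected to stay within the scatter, with no clear direction. Compound 3 is estimated at 5000 nM, with a range from 1500 nM to 16000 nM. The expected step is a 1.2-fold lower number from compound 1 to compound 3 (0.08 log units; within the scatter).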

Compound 3, half-maximal inhibitory concentration: 3400 nM
The estimate for compound 3 lay 1.5-fold (0.17 log units) above the measured number, within the range that was stated.
By their numbers in this assay, from the lowest: compounds 2, 3 and 1 (each within the scatter of the next).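

For the compounds shown here, the exchange of the (3-nitrophenyl)carbamoyl group for a group with sulfur in place of one oxygen, on the amine nitrogen, gives the first measured step at this position in this assay: a 1.8-fold lower number from compound 1 to compound 3 (0.25 log units; within the scatter). This single pair shows that this exchange leaves the read-out of the core of compound 1 within the scatter. No available measurement speaks to the reason for this result.

As far as these compounds go, it remains open whether a guanidine at this place would also stay within the scatter. From the compounds shown here alone, it also remains open whether the same exchange would do so on compound 2.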